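The compounds below may be only part of what the source reports. "The series", "measured", "known", "first", "only" and "open" are said of these compounds alone.

Measured compounds:
compound 1, `Cc1ccccc1-n1cc(CN2C(=O)C[C@@H]3CC[C@@]2(C)C3(C)C)nn1`, gives 150 nM;
compound 2, `COc1ccccc1-n1cc(CN2C(=O)C[C@@H]3CC[C@@]2(C)C3(C)C)nn1`, gives 140 nM;
compound 3, `CC1(C)[C@H]2CC[C@]1(C)N(Cc1cn(-c3cccc(Br)c3)nn1)C(=O)C2`, gives 30 nM.

All three share the same core and differ only in the aromatic ring attached to the nitrogen of the five-membered ring with three nitrogens. In a functional assay on OVCAR-3 cells (Homo sapiens) for inhibition, read by MTT assay, with a stated time of 24 h (a lower number here means a stronger inhibitor, a higher number a weaker inhibitor), compound 3 stands lowest of the three numbers, and both of its steps from the other compounds are beyond the scatter: a 5.0-fold lower number from compound 1 to compound 3 (0.70 log units; beyond the scatter) and a 4.7-fold lower number from compound 2 to compound 3 (0.67 log units; beyond the scatter). Between compound 1 and compound 2 the step is a 1.1-fold lower number from compound 1 to compound 2 (0.03 log units; within the scatter).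

Compound 4, `CC1(C)[C@H]2CC[C@]1(C)N(Cc1cn(-c3ccc(C#N)cc3)nn1)C(=O)C2`, has not been measured. It differs from compound 3 in one place: 4-cyanophenyl in place of 3-bromophenyl on an aromatic nitrogen.

The two steps that bear on this change are those leading to compound 3, since each of them also swaps the ring on that nitrogen. Among the compounds with values here, they show that the choice of group and its position on this ring can move the number by a modest amount, but no measured pair exchanges 3-bromophenyl for 4-cyanophenyl, so the direction is open. The expected step in this assay is therefore small, with the number for compound 4 estimated near that of compound 3 or somewhat higher: a 2.0-fold higher number from compound 3 to compound 4 (0.30 log units; within the scatter). Compound 4 is estimated at 60 nM, within a range from 20 nM to 200 nM.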

Compound 4, half-maximal inhibitory concentration: 380 nM
Estimate against measurement, compound 4: 6.3-fold (0.80 log units) below, outside the stated range (above it).
By their numbers in this assay, from the lowest: compound 3; then compounds 2 and 1 (each within the scatter of the next); then compound 4.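

In this assay, within the data shown here, the group on the aromatic nitrogen proves able to move the number much further than the earlier compounds revealed: the change brings a 13-fold higher number from compound 3 to compound 4 (1.10 log units; beyond the scatter), a large step that outstrips either step leading to compound 3. The 4-cyanophenyl group also falls behind both groups that had given the middle numbers, with a 2.7-fold higher number from compound 2 to compound 4 (0.43 log units; beyond the scatter) and a 2.5-fold higher number from compound 1 to compound 4 (0.40 log units; beyond the scatter), so among these four compounds the 3-bromophenyl ring gives the lowest number and the 4-cyanophenyl ring the highest, and simply having some group on the phenyl ring does not settle the outcome. Nothing available here explains why the number rises with this change.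

Compound 3 and compound 4 differ in both the group and its place on the ring, so a 3-cyanophenyl or a 4-bromophenyl group would be needed to tell these two parts of the change apart. As far as these compounds go, how an amine or a carboxylic acid on this phenyl ring would compare with the bromine and the nitrile also remains open.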